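A few compounds are considered here, and "the series" means these few. Any claim that something is new, unique, unknown or untested is made for them only; others in the source may bear on it.

Compound 1, `C#CCSc1nc(Nc2cccc(C(F)(F)F)c2)c(C#N)c(-c2ccccc2)n1` — > 128000 nM
Compound 2, `N#Cc1c(Nc2cccc(Cl)c2)nc(SCc2cn(Cc3ccccc3Cl)nn2)nc1-c1ccccc1` — 12000 nM

In a functional assay on MCF7 cells (Homo sapiens) for inhibition, read by MTT assay, with a stated time of 72 h (on this read-out higher numbers stand for weaker inhibition and lower numbers for stronger inhibition), compound 1 gives only a limit, > 128000 nM. Among the compounds with values here, compound 2 gives 12000 nM in this assay, the only number among the values shown. The other value shown is a limit, (the limit of > 128000 nM in this assay, at which 1 of the 2 values shown sits).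

Compound 3, `N#Cc1c(Nc2ccccc2)nc(SCc2cn(Cc3ccccc3Cl)nn2)nc1-c1ccccc1`, differs from compound 2 by hydrogen in place of chloro on an aromatic carbon. No step between measured compounds is shown, so the size of this change can only be expected: in this assay a modest weakening, or none beyond the scatter. Compound 3 is expected to give about 20000 nM in this assay, between 6000 nM and 65000 nM. This estimate means a step of a 1.7-fold higher number from compound 2 to compound 3 (0.22 log units; within the scatter), expected to stay near the scatter.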

Compound 3, half-maximal inhibitory concentration: > 64000 nM
Compound 3: only a limit was reported; the forecaster's own chance of this, stated with the estimate: 15%; middle value at least 3.2-fold (0.50 log units) from the limit.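

Going from 3-chlorophenyl to phenyl gives an at least 5.3-fold higher number from compound 2 to compound 3 (0.72 log units; beyond the scatter) in this assay, the only step that can be read here, and it shows that the chloro on this aromatic carbon matters by more than the scatter. Compound 3 gives only a limit: the limit of > 64000 nM in this assay, at which 1 of the 3 values shown sits.

As far as these compounds go, whether a fluoro or a methoxy group at this place would keep the number of compound 2 remains open. From the compounds shown here alone, how far the true number of compound 3 lies from its limit also remains open.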